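Adding a second trifluoromethyl group to compound 3

The source may hold more compounds than are shown below. What is called first, only, known or untested is meant among the compounds shown, and "the series" means these compounds.

Measured in an ADME assay on L132 cells (Homo sapiens) for inhibition, read by MTT assay, with a stated time of 72 h (a lower number here means a stronger inhibitor of growth, a higher number a weaker inhibitor of growth), so far
- compound 1 `Cc1cn(-c2cc(C(=O)Nc3cccc(C#Cc4cccc5[nH]nc(N)c45)c3)cc(C(F)(F)F)c2)cn1` gives 10900 nM
- compound 2 `Cc1ccc(C(=O)Nc2cccc(C#Cc3cccc4[nH]nc(N)c34)c2)cc1C(F)(F)F` gives > 100000 nM as a limit of the assay
- compound 3 `Nc1n[nH]c2cccc(C#Cc3cccc(C(=O)Nc4cccc(C(F)(F)F)c4)c3)c12` gives 15300 nM

On these numbers compound 3 at 15300 nM sits within the usual scatter of compound 1 at 10900 nM and no order can be drawn between the two. For compound 2 the read-out is > 100000 nM as a limit and not a number.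

The next compound is compound 4 `Nc1n[nH]c2cccc(C#Cc3cccc(C(=O)Nc4cc(C(F)(F)F)cc(C(F)(F)F)c4)c3)c12` and it differs from compound 3 by one change trifluoromethyl in place of hydrogen on an aromatic carbon with trifluoromethyl in place of hydrogen on an aromatic carbon, meta to a large group and meta to a trifluoromethyl group. Among the measured compounds shown here, no two measured compounds differ in only one place, so the series offers no measured step as a guide. In this assay no step beyond the scatter is expected, and the estimated change is a 1.2-fold higher number from compound 3 to compound 4 (0.07 log units; within the scatter) in size. This expectation takes compound 3 at 15300 nM as its starting point. The upper end is kept wide with compound 2 in view, whose > 100000 nM is a limit. For compound 4 the estimated value is 18000 nM with an expected range from 5000 nM to 80000 nM in this assay.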

Compound 4, concentration for 50% growth inhibition: > 100000 nM
Compound 4 ended at the assay's limit; the forecaster's own chance of this, stated with the estimate: 20%; middle value at least 5.5-fold (0.74 log units) from the limit.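

Among the compounds shown here, until now the series held no measured step, and this is its first: trifluoromethyl in place of hydrogen on an aromatic carbon, meta to a large group and meta to a trifluoromethyl group, gives an at least 6.5-fold higher number from compound 3 to compound 4 (0.81 log units; beyond the scatter) in this assay. The position is therefore not indifferent to this change, since the second trifluoromethyl group moves the read-out towards weaker inhibition of growth by more than the scatter. Compound 4 gives > 100000 nM, which is a limit of the assay and not a number, so the step fixes only a lower bound on its size, and the series now gathers at that limit: the limit of > 100000 nM in this assay, at which 2 of the 4 values shown sit.

Still open, on these data alone, is whether the shift belongs to trifluoromethyl itself or would also appear with another group on the same carbon, such as a fluorine atom, a methoxy group or an amine. Also open, as far as these compounds go, is how the read-out responds at this position to a change that keeps the value of the compound off the limit, which is what a measured size for the step would need.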